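Compound 4 and a change at the aromatic nitrogen side

A few compounds are considered here, and "the series" means these few. Any claim that something is new, unique, unknown or untested is made for them only; others in the source may bear on it.

Compound 1, `Cc1cc(Nc2cc(-c3ccccc3)[nH]n2)n2nc(SCc3nc4ccccc4[nH]3)nc2n1`, gives 1790 nM in a functional assay on MGC-803 cells (Homo sapiens) for inhibition, read by MTT assay, with a stated time of 72 h; a higher number here means a weaker inhibitor, a lower number a stronger inhibitor.
Compound 2, `Cc1cc(Nc2ccn(Cc3ccc(C(F)(F)F)cc3)n2)n2nc(SCc3ccc(Br)cc3)nc2n1`, gives 2590 nM in this assay.
Compound 3, `Cc1cc(Nc2cc(-c3ccccc3)[nH]n2)n2nc(SCc3ccc(Br)cc3)nc2n1`, gives 1110 nM in this assay.

Compound 2 has the highest of the three numbers in this assay. Its nearest neighbour is compound 1, which sits within the scatter of it, and its furthest is compound 3, whose lower number lies beyond the scatter.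

Compound 4, `Cc1cc(Nc2ccn(Cc3csc4ccc(Cl)cc34)n2)n2nc(SCc3ccc(Br)cc3)nc2n1`, has not yet been measured. It differs from compound 2 in one place: 5-chloro-1-benzothiophen-3-yl in place of 4-(trifluoromethyl)phenyl on a saturated chain carbon bound to an aromatic nitrogen.

Within the data shown here, only one step between measured compounds is known, a 1.6-fold lower number from compound 1 to compound 3 (0.21 log units; within the scatter). That step lies on the saturated chain carbon bound to a sulfur, on the other side of the shared core, and it falls within the scatter. Among the measured compounds shown here, no measured step touches the group on the saturated chain carbon bound to an aromatic nitrogen, so the record gives no direction for the change into compound 4. With nothing to point either way, compound 4 is expected to stay close to compound 2, with an expected step of a 1.1-fold lower number from compound 2 to compound 4 (0.03 log units; within the scatter) that does not exceed the scatter.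

Compound 4 is therefore estimated at 2400 nM in this assay, with a range from 1000 nM to 5800 nM.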

Compound 4, half-maximal inhibitory concentration: 1570 nM
The estimate for compound 4 lay 1.5-fold (0.18 log units) above the measured number; low and high end bracket the measured number.
By their numbers in this assay, from the lowest: compounds 3, 4, 1 and 2 (each within the scatter of the next, the first and the last beyond it).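

Among these compounds, the first measured step on the saturated chain carbon bound to an aromatic nitrogen is small: in this assay, 5-chloro-1-benzothiophen-3-yl in place of 4-(trifluoromethyl)phenyl gives a 1.6-fold lower number from compound 2 to compound 4 (0.22 log units; within the scatter). The two groups have the same count of heavy atoms but differ in their rings, one six-membered aromatic ring of carbon only against that ring joined by a five-membered aromatic ring with a hetero atom, and they also differ in chlorine and sulfur against fluorine, yet compound 2 and compound 4 cannot be told apart here. This single pair therefore shows that this position can carry either aromatic group without a step beyond the scatter, and nothing available explains this result or ties it to any property of the two groups.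

The compounds shown leave open whether that holds for groups of another kind at this position, such as an amine or a carboxylic acid on the saturated chain carbon bound to an aromatic nitrogen. They also leave open whether a longer chain between the aromatic nitrogen and the benzothiophene would keep the number within the scatter.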